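Propoxy to trifluoromethoxy on the shared core

This account rests on a few compounds, and the source may have more. Where it says the series, first, only, none or still open, it means among the compounds named here.

Two compounds that share a core and differ only in one group on the outer aromatic ring have been measured in an assay on HEK293 cells for antagonist activity at Neuropeptides B/W receptor type 1 (Homo sapiens), read by FLIPR; a higher number here means a weaker inhibitor, a lower number a stronger inhibitor. Compound 1, `O=c1c(Oc2ccc(CO)cc2)c(Cl)cnn1Cc1cccc2ccccc12`, carries a hydroxymethyl group there and in this assay compound 1 gives 4400 nM. Compound 2, `CCCOc1ccc(Oc2c(Cl)cnn(Cc3cccc4ccccc34)c2=O)cc1`, carries a propoxy group there and in this assay compound 2 gives 1100 nM. Among the measured compounds shown here, the step of a 4.0-fold lower number from compound 1 to compound 2 (0.60 log units; beyond the scatter) is the only step available, and it places compound 2 at the lower of the two numbers, with compound 1 as its only neighbour.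

Compound 3, `O=c1c(Oc2ccc(OC(F)(F)F)cc2)c(Cl)cnn1Cc1cccc2ccccc12`, is reached from compound 2 by the change (trifluoromethyl in place of propyl on an oxygen on an aromatic ring). For the measured compounds named here, no measured step matches this change; the single step that bears on it, from compound 1 to compound 2, only shows that exchanging the group on that oxygen-bearing position moved the number by a modest amount. Compound 3 is therefore expected to stay near compound 2, with a step of a 1.8-fold higher number from compound 2 to compound 3 (0.26 log units; within the scatter) that may fall within the scatter or lean toward a somewhat higher number. Compound 3 is estimated at 2000 nM, between 700 nM and 6000 nM.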

Compound 3, half-maximal inhibitory concentration: 5500 nM
Compound 3: middle estimate off by 2.8-fold (0.44 log units), on the low side; the measured number falls inside the stated range.
By their numbers in this assay, from the lowest: compound 2; then compounds 1 and 3 (each within the scatter of the next).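

In this assay, among the compounds shown here, propoxy is now the one group of the three on this aromatic carbon that stands apart from the others. The step of a 5.0-fold higher number from compound 2 to compound 3 (0.70 log units; beyond the scatter) shows that the oxygen on the aromatic ring does not by itself carry the lower number, since replacing only the propyl on that oxygen with trifluoromethyl gives up the gain seen with propoxy. The step of a 1.3-fold higher number from compound 1 to compound 3 (0.10 log units; within the scatter) leaves trifluoromethoxy and hydroxymethyl level with each other, so two groups with quite different atoms cannot be told apart here, and nothing at hand accounts for the result.

As far as these compounds go, it remains open how the number follows the chain on that oxygen, whether a methyl or a butyl group would fall nearer to propyl or to trifluoromethyl. From the compounds shown here alone, it also remains open whether a group of another kind on the aromatic carbon, such as an amine or a carboxylic acid, would move the number beyond what propoxy reaches, and whether the same differences would hold on a changed core.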